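The source may hold more compounds than are shown below. What is called first, only, known or untested is meant among the compounds shown, and "the series" means these compounds.

In a functional assay on MCF7 cells (Homo sapiens) for antiproliferative activity, read by MTT assay, with a stated time of 24 h (on this read-out higher numbers stand for weaker inhibition and lower numbers for stronger inhibition), compound 1 `CCn1c(C(=O)N[C@H](C)CO)ccc1C(CC)(CC)c1ccc(OCS(=O)(=O)c2ccccc2)c(C)c1` gives 10600 nM as its reading. With the higher of the two numbers, compound 2 `CCn1c(C(=O)N[C@H](CO)C(C)C)ccc1C(CC)(CC)c1ccc(OCS(=O)(=O)c2ccccc2)c(C)c1` gives 25500 nM and so shows the weaker inhibition. Compound 3 `CCn1c(C(=O)NCCCO)ccc1C(CC)(CC)c1ccc(OCS(=O)(=O)c2ccccc2)c(C)c1` has 3-hydroxypropyl in place of 1-(hydroxymethyl)-2-methylpropyl on an amide-type nitrogen. Among the compounds with values here, only one measured change bears on this, a 2.4-fold higher number from compound 1 to compound 2 (0.38 log units; beyond the scatter) (1-(hydroxymethyl)-2-methylpropyl in place of 1-(hydroxymethyl)ethyl), a modest step but beyond the scatter. A step of similar size in the opposite direction, toward a lower number, is expected (a 2.1-fold lower number from compound 2 to compound 3 (0.33 log units; beyond the scatter)). For compound 3 the estimated value is 12000 nM (range 5500 nM to 26000 nM).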

Compound 3, half-maximal inhibitory concentration: 42000 nM
Estimate against measurement, compound 3: 3.5-fold (0.54 log units) below, and the stated range ends below it.
By their numbers in this assay, from the lowest: compound 1; then compounds 2 and 3 (each within the scatter of the next).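

Swapping 1-(hydroxymethyl)-2-methylpropyl for the smaller 3-hydroxypropyl on the amide-type nitrogen gives a 1.6-fold higher number from compound 2 to compound 3 (0.22 log units; within the scatter), so this pair cannot be told apart. The smaller group also does not match compound 1, with a 4.0-fold higher number from compound 1 to compound 3 (0.60 log units; beyond the scatter), so at this position, fewer heavy atoms alone do not bring a lower number. Nothing measured here explains these differences. From the compounds shown here alone, whether an amine, a carboxylic acid or a longer chain on this nitrogen would give a lower number than compound 1 remains open.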